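Notes on the step from compound 2 to compound 3

The source may hold more compounds than are shown below. What is called first, only, known or untested is meant among the compounds shown, and "the series" means these compounds.

In a functional assay on PC-3 cells (Homo sapiens) for antiproliferative activity, read by MTT assay, with a stated time of 48 h (on this read-out higher numbers stand for weaker inhibition and lower numbers for stronger inhibition), compound 1 `COc1cc(N(Cc2ccc(C)cc2)C(=O)CSc2nc3ccccc3s2)cc(OC)c1OC` gives > 80000 nM as a limit. Compound 2 `COc1cc(CN(C(=O)CSc2nc3ccccc3s2)c2cc(OC)c(OC)c(OC)c2)cc(OC)c1OC` gives > 80000 nM as a limit too, so it stands without a number (the limit of > 80000 nM in this assay, at which 2 of the 2 values shown sit). Compound 3 `COc1ccc(CN(C(=O)CSc2nc3ccccc3s2)c2cc(OC)c(OC)c(OC)c2)cc1F` brings the change 3-fluoro-4-methoxyphenyl in place of 3,4,5-trimethoxyphenyl on a saturated chain carbon bound to an amide-type nitrogen with 3-fluoro-4-methoxyphenyl in place of 3,4,5-trimethoxyphenyl on a saturated chain carbon bound to an amide-type nitrogen. Going by the values given here, the one measured step at this place (a step that the two limits leave unreadable from compound 1 to compound 2) has no readable size, so little change and no firm direction are expected in this assay. The estimated step is an at least 1.3-fold lower number from compound 2 to compound 3 (0.12 log units; that floor lies within the scatter) and a limit reading remains likely. For compound 3 the estimate is 60000 nM with an expected range of 10000 nM to 120000 nM in this assay.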

Compound 3, half-maximal inhibitory concentration: 20100 nM
For compound 3 the middle estimate is 3.0-fold (0.47 log units) above the measured one, within the range that was stated.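

In this assay, the place on a saturated chain carbon bound to an amide-type nitrogen now gives a readable value: 3-fluoro-4-methoxyphenyl brings an at least 3.9-fold lower number from compound 2 to compound 3 (0.59 log units; beyond the scatter) and also an at least 3.9-fold lower number from compound 1 to compound 3 (0.59 log units; beyond the scatter). The step between compound 1 and compound 2 cannot be read. Both new steps are floors, and their true size stays unknown because each starts from a limit: the limit of > 80000 nM in this assay, at which 2 of the 3 values shown sit.

Whether the fluorine or the smaller number of methoxy groups accounts for the step stays open. Also open, on these data alone, is how a group carrying an amine or a carboxylic acid would read at this place.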